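Replacing thiophen-2-yl with 6-aminopyridin-3-yl in the series

The compounds below may be only part of what the source reports. "The series", "measured", "known", "first", "only" and "open" are said of these compounds alone.

Measured so far in a functional assay on MCF7 cells (Homo sapiens) for cytotoxicity, read by MTT assay, with a stated time of 48 h; a higher number here means a weaker inhibitor, a lower number a stronger inhibitor
- compound 1 `Cc1ncc([N+](=O)[O-])n1CCSc1nnc(-c2ccccc2)o1` gives 20500 nM
- compound 2 `COc1ccc(-c2nnc(SCCn3c([N+](=O)[O-])cnc3C)o2)cc1` gives 10600 nM
- compound 3 `Cc1ncc([N+](=O)[O-])n1CCSc1nnc(-c2cccs2)o1` gives 25800 nM

Compound 3 stands as follows: the numbers show a 1.3-fold higher number from compound 1 to compound 3 (0.10 log units; within the scatter) and a 2.4-fold higher number from compound 2 to compound 3 (0.39 log units; beyond the scatter) within the measured set. Compound 4 `Cc1ncc([N+](=O)[O-])n1CCSc1nnc(-c2ccc(N)nc2)o1` is not yet measured and carries 6-aminopyridin-3-yl in place of thiophen-2-yl on an aromatic carbon. Going by the values given here, no measured compound holds this group. The nearest guide is the remaining measured step, a 1.9-fold lower number from compound 1 to compound 2 (0.29 log units; within the scatter) together with the two above, none of them large. In this assay a small step, or none beyond the scatter, is therefore expected, with no firm direction. The estimated step is a 1.4-fold lower number from compound 3 to compound 4 (0.13 log units; within the scatter) as a working figure. Compound 4 is estimated at 19000 nM in a range from 8000 nM to 42000 nM for now.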

Compound 4, half-maximal inhibitory concentration: 26800 nM
Beside the measured number, compound 4's estimate is 1.4-fold (0.15 log units) below it, within the range that was stated.
By their numbers in this assay, from the lowest: compounds 2, 1, 3 and 4 (each within the scatter of the next, the first and the last beyond it).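

In this assay, going by these compounds alone, 6-aminopyridin-3-yl is the first group here to bring a hydrogen-bond donor to this position, and it leaves no step beyond the scatter against thiophen-2-yl (a 1.0-fold higher number from compound 3 to compound 4 (0.02 log units; within the scatter)) or phenyl (a 1.3-fold higher number from compound 1 to compound 4 (0.12 log units; within the scatter)). Only against 4-methoxyphenyl does the step pass the scatter, and modestly (a 2.5-fold higher number from compound 2 to compound 4 (0.40 log units; beyond the scatter)). With this donor in place, compound 4 shows no gain over compound 3.

On these data alone, whether a 4-aminophenyl or 4-carboxyphenyl group would move the number further remains open. No measurement on hand accounts for these steps.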